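Lengthening the acyl chain on a shared amide core

The compounds below may be only part of what the source reports. "The series", "measured", "known", "first", "only" and "open" are said of these compounds alone.

Compound 1 `CCC(=O)N(Cc1ccc(OC)c(O)c1)c1cc(OC)c(OC)c(OC)c1`: 61 nM
Compound 2 `C/C=C/C=C/C(=O)N(Cc1ccc(OC)c(O)c1)c1cc(OC)c(OC)c(OC)c1`: 180 nM
Compound 3 `COc1ccc(CN(C(C)=O)c2cc(OC)c(OC)c(OC)c2)cc1O`: 270 nM

The three compounds share one core and differ only in the group on the carbonyl carbon. In a functional assay on HCT-116 cells (Homo sapiens) for inhibition, read by MTT assay, with a stated time of 48 h (on this read-out higher numbers stand for weaker inhibition and lower numbers for stronger inhibition), compound 1 gives the lowest number of the three. Compound 3 gives the highest number; its nearest neighbour is compound 2, and the two lie within the scatter of each other, so no order can be drawn between them. The step of a 4.4-fold higher number from compound 1 to compound 3 (0.65 log units; beyond the scatter) lies beyond the scatter, as does a 3.0-fold higher number from compound 1 to compound 2 (0.47 log units; beyond the scatter), while a 1.5-fold higher number from compound 2 to compound 3 (0.18 log units; within the scatter) does not.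

Compound 4 `COc1ccc(CN(C(=O)CCCCCl)c2cc(OC)c(OC)c(OC)c2)cc1O` carries the change (3-chloropropyl in place of hydrogen on a saturated chain carbon bound to a carbonyl carbon). Among the measured compounds shown here, the step that bears on it most directly is the one between compound 1 and compound 3, where a methyl on that same saturated chain carbon went along with the lower number of compound 1. Compound 4 goes further along the chain than compound 1 does, and the steps shown do not tell whether the gain seen with compound 1 persists or fades. Compound 4 is therefore expected to give a number between those of compound 1 and compound 3, with the step of a 2.3-fold lower number from compound 3 to compound 4 (0.35 log units; beyond the scatter) as the estimate. The estimate for compound 4 in this assay is 120 nM, with a range from 45 nM to 320 nM.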

Compound 4, half-maximal inhibitory concentration: 220 nM
Compound 4: the middle estimate sits 1.8-fold (0.26 log units) below what was measured, within the range that was stated.
By their numbers in this assay, from the lowest: compound 1; then compounds 2, 4 and 3 (each within the scatter of the next).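

In this assay, the 3-chloropropyl group on the saturated chain carbon bound to a carbonyl carbon gives a 1.2-fold lower number from compound 3 to compound 4 (0.09 log units; within the scatter), so at this position the longer chlorinated chain cannot be told apart from hydrogen, whereas a methyl there, in compound 1, was linked to a clear difference, seen in a 4.4-fold higher number from compound 1 to compound 3 (0.65 log units; beyond the scatter). The 4-chlorobutyl group on the carbonyl carbon also cannot be told apart from the penta-1,3-dien-1-yl group, with a 1.2-fold higher number from compound 2 to compound 4 (0.09 log units; within the scatter), while compound 1 stays apart from the chlorinated compound, with a 3.6-fold higher number from compound 1 to compound 4 (0.56 log units; beyond the scatter). Extending the chain therefore does not carry the lower number of compound 1 any further: of the four groups on the carbonyl carbon only the ethyl group of compound 1 stands out, and compounds 2, 3 and 4 form one group within the scatter.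

The compounds shown leave open whether a plain propyl or butyl chain on the carbonyl carbon, with no chlorine, would stay with compound 1 or with compound 4, and whether an amine or a carboxylic acid at the end of the chain would shift the number. Nothing shown gives a reason for the difference between the ethyl group and the other groups.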